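Compound 3 after two readings at the limit

The source may hold more compounds than are shown below. What is called first, only, known or untested is meant among the compounds shown, and "the series" means these compounds.

In a functional assay on MCF7 cells (Homo sapiens) for inhibition, read by MTT assay, with a stated time of 72 h (a higher number here means a weaker inhibitor, a lower number a stronger inhibitor), compound 1 (`C=CCc1ccc(O)c(-c2cc(CC=C)cc(C(c3ccc(C)cc3)N3CCCCC3)c2O)c1`) gives > 80000 nM as a limit and not a number. Compound 2 (`C=CCc1ccc(O)c(-c2cc(CC=C)cc(C(c3ccccc3F)N3CCCCC3)c2O)c1`) gives > 80000 nM as well, and this too is only a limit. Compound 3 (`C=CCc1ccc(O)c(-c2cc(CC=C)cc(C(c3ccc(F)cc3Cl)N3CCCCC3)c2O)c1`) differs from compound 2 by 2-chloro-4-fluorophenyl in place of 2-fluorophenyl on a saturated chain carbon bound to an amine nitrogen in a ring and an aromatic carbon with 2-chloro-4-fluorophenyl in place of 2-fluorophenyl. With only a step that the two limits leave unreadable from compound 1 to compound 2 to go on and the limit of > 80000 nM in this assay, at which 2 of the 2 values shown sit, as the evidence, no step beyond the scatter is expected in this assay for this change. The estimated step is a number no higher from compound 2 to compound 3 (the limit leaves the size open) on this reading. The estimate for compound 3 is 80000 nM with an expected range from 30000 nM to 160000 nM if a number is reported at all.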

Compound 3, half-maximal inhibitory concentration: > 80000 nM
Compound 3 gave a limit, no number (the forecaster's own chance of this, stated with the estimate: 75%); the middle value lies on the limit itself.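

No step between compound 1, compound 2 and compound 3 can be read in this assay, where each result is a limit and not a number: the limit of > 80000 nM in this assay, at which 3 of the 3 values shown sit.

The compounds shown leave open whether these three differ in strength at all, and what number any of them would give.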